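Putting oxan-2-yl on the hydroxy of compound 2

The source may hold more compounds than are shown below. What is called first, only, known or untested is meant among the compounds shown, and "the series" means these compounds.

Measured in a functional assay on HeLa cells (Homo sapiens) for antiproliferative activity; on this read-out lower numbers stand for stronger inhibition and higher numbers for weaker inhibition:
- compound 1 `CC(=O)O[C@@H]1/C=C(\C)CC[C@]2([C@@](C)(O)C(=O)SCc3oc(=O)oc3C)CC(=O)N([C@H](C)c3nc(cs3)/C=C/C=C/C1=O)[S+]2[O-]`: 3.9 nM
- compound 2 `C/C1=C\[C@@H](O)C(=O)/C=C/C=C/c2csc(n2)[C@@H](C)N2C(=O)C[C@@]([C@@](C)(O)C(=O)SCc3oc(=O)oc3C)(CC1)[S+]2[O-]`: 4.6 nM

Compound 2 has only compound 1 for comparison, and their two values lie within the scatter of each other. Compound 3 `C/C1=C\[C@@H](O[C@H]2CCCCO2)C(=O)/C=C/C=C/c2csc(n2)[C@@H](C)N2C(=O)C[C@@]([C@@](C)(O)C(=O)SCc3oc(=O)oc3C)(CC1)[S+]2[O-]` differs from compound 2 as follows: oxan-2-yl in place of hydrogen on an oxygen on a saturated carbon. For the measured compounds named here, the one measured step bearing on this, a 1.2-fold higher number from compound 1 to compound 2 (0.07 log units; within the scatter), is hydrogen in place of acetyl at that same kind of place. Going by the values given here, no measured compound carries oxan-2-yl, so this guide is rough, and no step beyond the scatter is expected in this assay. The expected step is a 1.2-fold higher number from compound 2 to compound 3 (0.08 log units; within the scatter). For compound 3 the estimate is 5.5 nM, with an expected range of 2.5 nM to 15 nM.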

Compound 3, half-maximal inhibitory concentration: 2.4 nM
Compound 3: the middle estimate sits 2.3-fold (0.36 log units) above what was measured; the whole stated range lies above it.
By their numbers in this assay, from the lowest: compounds 3, 1 and 2 (each within the scatter of the next).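

In this assay, the oxygen on a saturated carbon takes a six-membered oxan-2-yl ring in place of hydrogen, with a 1.9-fold lower number from compound 2 to compound 3 (0.28 log units; within the scatter), a step still within the scatter. Against the acetyl of compound 1, a 1.6-fold lower number from compound 1 to compound 3 (0.21 log units; within the scatter) is also within the scatter, so hydrogen, acetyl and oxan-2-yl at this oxygen cannot be told apart on this read-out. Nothing available explains this tolerance. Going by these compounds, whether a methyl ether, a longer alkyl chain or a group carrying an amine would also stay within the scatter remains open. So does the effect of the opposite arrangement at the stereocentre of oxan-2-yl.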